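Acetyl on the hydroxymethyl group of compound 2

The compounds below may be only part of what the source reports. "The series", "measured", "known", "first", "only" and "open" are said of these compounds alone.

In a functional assay on A549 cells (Homo sapiens) for cytotoxicity, read by MTT assay, with a stated time of 72 h (a lower number here means that less compound is needed, a higher number that more compound is needed for the effect), compound 1 (`CCc1cccc2c(OC)c(-c3occ(C)c3C(=S)OC)ccc12`) gives 6.2 ug/mL. Within the data shown here, compound 2 (`CCc1cccc2c(OC)c(-c3occ(C)c3CO)ccc12`) gives 9.6 ug/mL, and these two values lie within the scatter of each other, so compound 2 stands level with the only other measured compound. Compound 3 (`CCc1cccc2c(OC)c(-c3occ(C)c3COC(C)=O)ccc12`) is compound 2 with acetyl in place of hydrogen on an oxygen on a saturated carbon, which turns hydroxymethyl to acetoxymethyl: acetyl in place of hydrogen on an oxygen on a saturated carbon. Among the measured compounds shown here, no measured compound pair shows this change directly. For the measured compounds named here, the one measured step that bears on it, a 1.5-fold higher number from compound 1 to compound 2 (0.19 log units; within the scatter), alters the same substituent and stays small, so no shift beyond the scatter is expected in this assay, in either direction. The estimated change is a 1.2-fold lower number from compound 2 to compound 3 (0.08 log units; within the scatter). For compound 3 the estimate is 8 ug/mL, with an expected range from 3.5 ug/mL to 18 ug/mL.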

Compound 3, concentration for half-maximal effect: > 10 ug/mL
Compound 3 gave a limit, no number; the forecaster's own chance of this, stated with the estimate: 5%; at least 1.2-fold (0.09 log units) between middle value and limit.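

Compound 3 is the first compound here with a substituent on the hydroxymethyl oxygen, and it gives a limit and not a number: the limit of > 10 ug/mL in this assay, at which 1 of the 3 values shown sits.

Acetyl in place of hydrogen on that oxygen reads as an at least 1.0-fold higher number from compound 2 to compound 3 (0.01 log units; that floor lies within the scatter), and the change from the group carried by compound 1 reads as an at least 1.6-fold higher number from compound 1 to compound 3 (0.20 log units; that floor lies within the scatter). Both floors lie within the scatter, so in this assay acetoxymethyl can be neither separated from the groups of compound 1 and compound 2 nor shown to stand apart from them.

From the compounds shown here alone, the true size of the acetyl step remains open, since only its floor is known. The compounds shown also leave open how a methyl ether, an amine or a carboxylic acid at this place would read in this assay.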